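A few compounds are considered here, and "the series" means these few. Any claim that something is new, unique, unknown or untested is made for them only; others in the source may bear on it.

Measured compounds:
compound 1 `CCn1c(C(=O)NCCCN(C)C)ccc1C(CC)(CC)c1ccc(OCC(O)C(C)(C)C)c(C)c1`: 470 nM
compound 2 `CCn1c(C(=O)NCCN)ccc1C(CC)(CC)c1ccc(OCC(O)C(C)(C)C)c(C)c1`: 2400 nM
compound 3 `CCn1c(C(=O)N(C)CC(=O)O)ccc1C(CC)(CC)c1ccc(OCC(=O)C(C)(C)C)c(C)c1`: 8700 nM

In an ADME assay on L02 cells (Homo sapiens) for cytotoxicity, read by MTT assay, with a stated time of 48 h (on this read-out higher numbers stand for weaker inhibition and lower numbers for stronger inhibition), compound 1 gives the lowest of the three numbers; compound 2 sits nearest to it and compound 3 furthest away. The unmeasured compound 4 `CC[C@@H](C)[C@H](NC(=O)c1ccc(C(CC)(CC)c2ccc(OCC(O)C(C)(C)C)c(C)c2)n1CC)C(=O)O` differs from compound 1 in one place: 1-carboxy-2-methylbutyl in place of 3-(dimethylamino)propyl on an amide-type nitrogen. Going by the values given here, one measured step bears on this change. Going a 5.1-fold higher number from compound 1 to compound 2 (0.71 log units; beyond the scatter) shows that taking the dimethylamino group away from the chain on the amide-type nitrogen raises the number well beyond the scatter. Compound 3, which also carries a carboxylic acid on that nitrogen, gives 8700 nM in this assay, but it differs from compound 1 in a second place too, so its two values can only be read side by side. Compound 4 loses the dimethylamino group and gains a carboxylic acid, so the step is expected to go upward, beyond the scatter. Compound 4 is therefore estimated at 5000 nM, with a range of 1500 nM to 17000 nM, which means an expected step of an 11-fold higher number from compound 1 to compound 4 (1.03 log units; beyond the scatter).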

Compound 4, half-maximal inhibitory concentration: 1400 nM
Compound 4: middle estimate off by 3.6-fold (0.55 log units), on the high side; measured number below the stated range.
By their numbers in this assay, from the lowest: compound 1; then compounds 4 and 2 (each within the scatter of the next); then compound 3.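

In this assay the step of a 3.0-fold higher number from compound 1 to compound 4 (0.47 log units; beyond the scatter) shows that a chain carrying a carboxylic acid on the amide-type nitrogen, here 1-carboxy-2-methylbutyl, still lies beyond the scatter from 3-(dimethylamino)propyl, though the step is only modest. The step of a 1.7-fold lower number from compound 2 to compound 4 (0.23 log units; within the scatter) stays within the scatter, so at this position the read-out does not separate 1-carboxy-2-methylbutyl, with its carboxylic acid, from 2-aminoethyl, with its amine. Nothing measured here explains either step.

The compounds shown leave open how much of the step from compound 1 goes with losing the dimethylamino group and how much with gaining the carboxylic acid or the branched chain. Also open, from the compounds shown here alone, is how a dimethylamino group on a longer chain, or a plain alkyl chain, would read at this nitrogen.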